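Swapping isopropyl for oxetan-3-yl on an aromatic oxygen

The compounds below may be only part of what the source reports. "The series", "measured", "known", "first", "only" and "open" are said of these compounds alone.

- compound 1 `CCOc1cc(-c2ccc3[nH]ccc3c2)cn2c(-c3cc(OC)c(OC)c(OC)c3)nnc12` gives 374 nM as its value
- compound 2 `COc1cc(-c2nnc3c(OC(C)C)cc(-c4ccc5[nH]ccc5c4)cn23)cc(OC)c1OC` gives 939 nM as its value

In a functional assay on HCT-116 cells (Homo sapiens) for antiproliferative activity, read by MTT assay, with a stated time of 48 h (a higher number here means a weaker inhibitor, a lower number a stronger inhibitor), compound 2 stands at 939 nM and has the higher of the two numbers, which makes it the weaker inhibitor of the pair. Among the compounds with values here, the only measured step is a 2.5-fold higher number from compound 1 to compound 2 (0.40 log units; beyond the scatter) and it came from a methyl in place of hydrogen on a saturated chain carbon bound to an oxygen on an aromatic ring.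

Compound 3 `COc1cc(-c2nnc3c(OC4COC4)cc(-c4ccc5[nH]ccc5c4)cn23)cc(OC)c1OC` keeps the shared core and alters the group on that same oxygen, and the change is oxetan-3-yl in place of isopropyl on an oxygen on an aromatic ring with oxetan-3-yl in place of isopropyl. Within the data shown here, the modest measured step is the sole guide, and no measured compound carries an oxetan-3-yl group. In this assay a small move toward a lower number is therefore expected, smaller than the measured step and perhaps not beyond the scatter. The expected change is a 1.7-fold lower number from compound 2 to compound 3 (0.23 log units; within the scatter) in this estimate. The estimated value for compound 3 is 550 nM with an expected range of 200 nM to 1500 nM for repeat measurements.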

Compound 3, half-maximal inhibitory concentration: 5370 nM
Compound 3: the middle estimate sits 9.8-fold (0.99 log units) below what was measured, and the stated range ends below it.
By their numbers in this assay, from the lowest: compound 1; then compound 2; then compound 3.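

In this assay, replacing isopropyl with oxetan-3-yl on the aromatic oxygen gives a 5.7-fold higher number from compound 2 to compound 3 (0.76 log units; beyond the scatter), a larger move than the earlier step and in the opposite direction from the small gain that had seemed likely. Against the ethyl group, the same oxetan-3-yl group gives a 14-fold higher number from compound 1 to compound 3 (1.16 log units; beyond the scatter), which makes compound 3 the weakest inhibitor of the three. This position therefore responds clearly to the group placed on it, since ethyl, isopropyl and oxetan-3-yl all give numbers that lie beyond the scatter of one another, and the trend among these three compounds runs toward weaker inhibition from ethyl to isopropyl to oxetan-3-yl.

The compounds shown cannot separate the effect of the four-membered ring itself from that of the oxygen within it, a question that a cyclobutyl group on this oxygen could address, and they do not show whether a methyl group, smaller than ethyl, would give a lower number still. Nothing available here accounts for the loss seen with the oxetan-3-yl group.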